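The compounds below may be only part of what the source reports. "The series", "measured", "known", "first", "only" and "open" are said of these compounds alone.

Measured compounds in a functional assay on Jurkat cells (Homo sapiens); a higher number here means a weaker inhibitor, a lower number a stronger inhibitor:
compound 1 `CC(C)[C@H](NC(=O)COc1cccc2ccccc12)C(=O)N[C@@H](CC(=O)O)C(=O)COc1ccc(Oc2ccccc2)cc1` gives 12700 nM
compound 2 `CC(C)[C@H](NC(=O)COc1cccc2ccccc12)C(=O)N[C@@H](CC(=O)O)C(=O)COc1ccc(OC(F)(F)F)cc1` gives 29100 nM
compound 3 `CC(C)[C@H](NC(=O)COc1cccc2ccccc12)C(=O)N[C@@H](CC(=O)O)C(=O)COc1ccc(Oc2ccc(C(F)(F)F)cc2)cc1` gives 9300 nM

Compound 2 stands with the highest number of the three: a 2.3-fold higher number from compound 1 to compound 2 (0.36 log units; beyond the scatter), and a 3.1-fold lower number from compound 2 to compound 3 (0.50 log units; beyond the scatter). Between compounds 1 and 3 the step is small, a 1.4-fold lower number from compound 1 to compound 3 (0.14 log units; within the scatter).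

Compound 4 `CC(C)[C@H](NC(=O)COc1cccc2ccccc12)C(=O)N[C@@H](CC(=O)O)C(=O)COc1ccc(F)c(F)c1F` is not yet measured. Its change from compound 2: 2,3,4-trifluorophenyl in place of 4-(trifluoromethoxy)phenyl on an oxygen on a saturated carbon

The measured steps touch the same oxygen on a saturated carbon, but none of them puts a plain fluorinated ring there without a further group on an oxygen. The two steps that bear on it, from compound 1 to compound 2 and from compound 2 to compound 3, each moved the number modestly, and in opposite directions, so the replacement by 2,3,4-trifluorophenyl carries no clear direction from the data. In this assay a step of a 1.2-fold lower number from compound 2 to compound 4 (0.07 log units; within the scatter) is expected, which is within the scatter, though the range is wide. Compound 4 is therefore estimated at 25000 nM, between 8000 nM and 80000 nM.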

Compound 4, half-maximal inhibitory concentration: 35800 nM
For compound 4 the middle estimate is 1.4-fold (0.16 log units) below the measured one, within the range that was stated.
By their numbers in this assay, from the lowest: compounds 3 and 1 (each within the scatter of the next); then compounds 2 and 4 (each within the scatter of the next).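

In this assay, 2,3,4-trifluorophenyl in place of 4-(trifluoromethoxy)phenyl on an oxygen on a saturated carbon gives a 1.2-fold higher number from compound 2 to compound 4 (0.09 log units; within the scatter), so these two fluorinated rings cannot be told apart at this position. Among the compounds shown here, this is the first comparison here in which the ring at this place changes without the group on an oxygen on that ring being the only thing altered, and compound 2 and compound 4 together hold the higher numbers of the set, with compound 1 and compound 3 holding the lower numbers. No measurement on hand accounts for the two rings reading alike.

Going by these compounds, whether this position responds at all to a ring bearing an amine or a carboxylic acid in place of the fluorines remains open. Also open, on these data alone, is whether an unsubstituted phenyl would read the same as compound 4 in this assay.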